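The compounds below may be only part of what the source reports. "The series", "measured", "known", "first", "only" and "open" are said of these compounds alone.

Of the compounds shown here, three have been measured in a toxicity assay on J774.1 cells (Mus musculus) for cytotoxicity, read by MTT assay, with a stated time of 48 h; a higher number here means that more compound is tolerated, a lower number that less compound is tolerated. Compound 1 `O=C(NCc1ccccc1C(=O)N[C@H](/C=C/S(=O)(=O)c1ccccc1)CCc1ccccc1)c1cccc(O)c1` gives 36000 nM. Compound 2 `CC(=O)N(Cc1ccccc1C(=O)N[C@H](/C=C/S(=O)(=O)c1ccccc1)CCc1ccccc1)C(C)=O` gives 36000 nM, and no change at the digits printed from compound 1 to compound 2 (within the scatter). For compound 3 `O=C(NCc1ccccc1C(=O)N[C@H](/C=C/S(=O)(=O)c1ccccc1)CCc1ccccc1)c1ccccc1` only a limit is returned in this assay, > 100000 nM. Compound 3 sits at the limit of > 100000 nM in this assay, at which 1 of the 3 values shown sits. Compound 3 thus stands at the tolerant end of the numbers shown: an at least 2.7-fold higher number from compound 1 to compound 3 (0.44 log units; beyond the scatter), and an at least 2.7-fold higher number from compound 2 to compound 3 (0.44 log units; beyond the scatter).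

Compound 4 `O=C(O)c1cccc(C(=O)NCc2ccccc2C(=O)N[C@H](/C=C/S(=O)(=O)c2ccccc2)CCc2ccccc2)c1` differs from compound 3 by carboxy in place of hydrogen on an aromatic carbon. The step that bears most directly on this change runs the other way, from a substituted to a bare ring on the same aromatic carbon: an at least 2.7-fold higher number from compound 1 to compound 3 (0.44 log units; beyond the scatter). Placing a carboxy there is therefore expected to move the number back downward, roughly undoing that step, though the limit on compound 3 leaves its true size open. The expected step is an at least 1.6-fold lower number from compound 3 to compound 4 (0.22 log units; that floor lies within the scatter). Compound 4 is estimated to give about 60000 nM, with a plausible range of 25000 nM to 140000 nM.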

Compound 4, half-maximal cytotoxic concentration: > 100000 nM
Compound 4: no number, only a limit; the forecaster's own chance of this, stated with the estimate: 35%; at least 1.6-fold (0.22 log units) between middle value and limit.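

Carboxy in place of hydroxy on this aromatic carbon gives an at least 2.7-fold higher number from compound 1 to compound 4 (0.44 log units; beyond the scatter) in this assay, so the lower tolerance seen with hydroxy in compound 1 does not extend to every group at this place. Replacing the diacetylamino group with the ((3-carboxyphenyl)carbonyl)amino group gives an at least 2.7-fold higher number from compound 2 to compound 4 (0.44 log units; beyond the scatter), which places the carboxy compound with the bare benzamide rather than with compound 1 or compound 2. The step between compound 3 and compound 4 cannot be read, since both return only a limit: the limit of > 100000 nM in this assay, at which 2 of the 4 values shown sit.

Going by these compounds, whether carboxy changes tolerance at all relative to hydrogen stays open, as does how far the true values of compound 3 and compound 4 lie past that limit. Also open, on these data alone, is whether an amine or a methyl ester at this place would follow hydroxy or carboxy.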